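Amine variation on a stilbene ether series in electroshock

The source may hold more compounds than are shown below. What is called first, only, known or untested is meant among the compounds shown, and "the series" means these compounds.

Measured compounds and values:
compound 1, `CN(C)CCCCOc1ccccc1/C=C/c1cccc(Cl)c1`, 14.3%
compound 2, `CN1CCN(CCCCOc2ccccc2/C=C/c2cccc(Cl)c2)CC1`, 0%
compound 3, `CN1CCN(CCCCOc2ccccc2/C=C/c2ccc(Cl)c(Cl)c2)CC1`, 0%

The read-out throughout is a functional assay on the whole organism with Mus musculus as the target, in the maximal electroshock model, at a dose of 50 mg/kg by the oral route; on this read-out higher numbers stand for more inhibition at the one dose given (going by the name of the read-out) and lower numbers for less inhibition. Compound 2 stands level with compound 3 at the digits reported; together they give the lowest of the three numbers, and compound 1 is the only one clearly apart, the gap being a number 14.3 percentage points lower from compound 1 to compound 2 (beyond the scatter). The change from compound 2 to compound 3, chloro in place of hydrogen on an aromatic carbon, gave no change at the digits printed from compound 2 to compound 3 (within the scatter).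

Compound 4, `OC1CCCN(CCCCOc2ccccc2/C=C/c2cccc(Cl)c2)C1`, is not yet measured in this assay. The change from compound 2 reads (3-hydroxypiperidin-1-yl in place of 4-methylpiperazin-1-yl on a saturated chain carbon, four bonds along the chain from an oxygen on an aromatic ring). Among the measured compounds shown here, no measured step swaps one ring amine for another; the only step at this position of the chain is a number 14.3 percentage points lower from compound 1 to compound 2 (beyond the scatter), which shows that altering the amine moves the number modestly. A modest step upward or none beyond the scatter is therefore expected in this assay, as a number 8 percentage points higher from compound 2 to compound 4 (within the scatter). Compound 4 is thus estimated at 8%, within the range 0% to 30%.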

Compound 4, a percentage reported as inhibition, in the whole organism at one dose (the size of the read-out at that dose, not a potency): 12.5%
The estimate for compound 4 lay 4.5 percentage points below the measured number, and the stated range covers the measured number.
By their numbers in this assay, from the lowest: compounds 2 and 3 (each within the scatter of the next); then compounds 4 and 1 (each within the scatter of the next).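

In this assay, ring amines at this position can be told apart: with 3-hydroxypiperidin-1-yl in place of 4-methylpiperazin-1-yl, the result is (a number 12.5 percentage points higher from compound 2 to compound 4 (beyond the scatter)). A six-membered ring on this saturated chain carbon therefore does not by itself hold the number at the level of compound 2, and the swap from dimethylamino to 3-hydroxypiperidin-1-yl gives (a number 1.8 percentage points lower from compound 1 to compound 4 (within the scatter)). No measurement in hand bears on the reason for either step.

Still open, on these data alone, is whether the hydroxy group or the other ring atoms carry the step, a question that piperidin-1-yl without the hydroxy group and morpholin-4-yl on the same chain would address. Also open, as far as these compounds go, is whether 3-hydroxypiperidin-1-yl keeps its number alongside the added chloro of compound 3.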